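Phenylselanyl in Place of Hexynyl on a Quinoline Ester

This account rests on a few compounds, and the source may have more. Where it says the series, first, only, none or still open, it means among the compounds named here.

In a functional assay on SK-MEL-147 cells (Homo sapiens) for cytotoxicity, read by MTT assay, with a stated time of 24 h (on this read-out lower numbers stand for an effect already at smaller amounts and higher numbers for an effect only at larger amounts of compound), compound 1 `CCCCC#Cc1cc(C(=O)OCC)nc2ccc(OC)cc12` gives 7200 nM, the lowest of the two numbers reported. Compound 3 `CCOC(=O)c1cc([Se]c2ccccc2)c2cc(C)ccc2n1` gives 12000 nM in this assay, within the scatter of compound 1. Compound 2 `COc1ccc2nc(-c3c(Cl)cccc3Cl)cc([Se]c3ccccc3)c2c1` gives > 150000 nM in this assay, which is the limit of > 150000 nM in this assay, at which 1 of the 3 values shown sits, and not a number. Compound 4 `CCOC(=O)c1cc([Se]c2ccccc2)c2cc(OC)ccc2n1` has not yet been measured. It differs from compound 1 in one place: a group of 7 heavy atoms (6 carbon, 1 selenium; one six-membered aromatic ring of carbon only) in place of a group of 6 heavy atoms (6 carbon; no ring), on an aromatic carbon. Going by the values given here, no measured pair shows this change alone, so the expected step is a 1.5-fold higher number from compound 1 to compound 4 (0.18 log units; within the scatter), judged from compound 3, whose value of 12000 nM sits close to compound 1. Compound 4 is therefore estimated at 11000 nM in this assay, with a likely range from 4000 nM to 30000 nM.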

Compound 4, half-maximal effective concentration: 33000 nM
For compound 4 the middle estimate is 3.0-fold (0.48 log units) below the measured one, outside the stated range (above it).
By their numbers in this assay, from the lowest: compounds 1 and 3 (each within the scatter of the next); then compound 4. At a limit, above all of these: compound 2.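

At the aromatic carbon opposite the ring nitrogen, the selenium-bearing group in place of hex-1-yn-1-yl gives a 4.6-fold higher number from compound 1 to compound 4 (0.66 log units; beyond the scatter) in this assay, so this change is not neutral on the core of compound 1. Methoxy in place of methyl gives a 2.8-fold higher number from compound 3 to compound 4 (0.44 log units; beyond the scatter) with the selenium-bearing group held fixed, so compound 3 does not stand in for compound 4. Ethoxycarbonyl in place of 2,6-dichlorophenyl gives an at least 4.5-fold lower number from compound 2 to compound 4 (0.65 log units; beyond the scatter) and is read against a limit, not a number: the limit of > 150000 nM in this assay, at which 1 of the 4 values shown sits.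

On these data alone, whether an amine or a carboxylic acid in place of the ethoxycarbonyl group would shift the number stays open. So does how a longer chain than hex-1-yn-1-yl would read at this carbon.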